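A few compounds are considered here, and "the series" means these few. Any claim that something is new, unique, unknown or untested is made for them only; others in the source may bear on it.

Working notes on the series. Among the measured compounds shown here, in an ADME assay on HEK293 cells (Homo sapiens) for cytotoxicity, read by resazurin assay, with a stated time of 48 h (on this read-out higher numbers stand for lower toxicity in this test and lower numbers for higher toxicity in this test), compound 1 `O=S(=O)(Nc1ccc2oc(-c3ccccc3)nc2c1)c1cccc(F)c1` gives 68000 nM, the only numerical value so far. Compound 2 `O=S(=O)(Nc1ccc(-c2nc3ccccc3o2)cc1)c1ccccc1F` reads > 100000 nM, which is a limit of the assay and not a number. For the measured compounds named here, the two compounds therefore offer no measured step in this assay from which to size a change.

Compound 3 `O=S(=O)(Nc1ccc2oc(-c3ccccc3)nc2c1)c1cccc(O)c1` differs from compound 1 in one place: hydroxy in place of fluoro on an aromatic carbon. This puts hydroxy in place of fluoro on an aromatic carbon, meta to a large group.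

Going by the values given here, with no measured step to draw on, the expectation rests on compound 1 at 68000 nM. The step of a 1.1-fold higher number from compound 1 to compound 3 (0.04 log units; within the scatter) is expected to stay within the usual scatter, with no firm direction. For compound 3 the estimated value is 75000 nM, with an expected range of 35000 nM to 130000 nM.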

Compound 3, half-maximal cytotoxic concentration: > 100000 nM
Compound 3 was reported as a limit (the forecaster's own chance of this, stated with the estimate: 35%); at least 1.3-fold (0.12 log units) between middle value and limit.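

In this assay, among the compounds shown here, the change from 3-fluorophenyl to 3-hydroxyphenyl gives the first readable step: an at least 1.4-fold higher number from compound 1 to compound 3 (0.16 log units; that floor lies within the scatter) and that step has only a floor. At this place, on an aromatic carbon meta to a large group, hydroxy gives no lower number than fluoro, so the entering hydrogen-bond donor and acceptor bring no sign of higher toxicity in this test. The value of compound 3 is a limit of the assay and not a number, and with the floor of the step within the scatter, no real rise can be claimed.

As far as these compounds go, whether an amine, a carboxylic acid or a methoxy group at this place would hold the number at this level remains open. How far compound 3 lies past its limit also remains open, since the read-out ends there: the limit of > 100000 nM in this assay, at which 2 of the 3 values shown sit.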